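Methoxy to Chloro: Estimating Compound 4 from Compound 3

This account rests on a few compounds, and the source may have more. Where it says the series, first, only, none or still open, it means among the compounds named here.

Measured compounds:
compound 1, `C#CCSc1nc(Nc2cccc(C(F)(F)F)c2)c(C#N)c(-c2ccccc2)n1`: > 128000 nM
compound 2, `C#CCSc1nc(Nc2cccc(Cl)c2)c(C#N)c(-c2ccccc2)n1`: > 128000 nM
compound 3, `COc1ccc(Nc2nc(SCc3cn(Cc4ccccc4Cl)nn3)nc(-c3ccccc3)c2C#N)cc1`: 7560 nM

In a functional assay on MGC-803 cells (Homo sapiens) for inhibition, read by MTT assay, with a stated time of 72 h (a lower number here means a stronger inhibitor, a higher number a weaker inhibitor), compound 1 returns only a limit, > 128000 nM. In this assay compound 2 likewise returns only a limit, > 128000 nM. The step that the two limits leave unreadable from compound 1 to compound 2 is therefore unreadable, as the limit of > 128000 nM in this assay, at which 2 of the 3 values shown sit, shows. For the measured compounds named here, compound 3 stands alone as the one compound with an actual number in this assay, namely 7560 nM.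

Compound 4, `N#Cc1c(Nc2ccc(Cl)cc2)nc(SCc2cn(Cc3ccccc3Cl)nn2)nc1-c1ccccc1`, differs from compound 3 by chloro in place of methoxy on an aromatic carbon. Going by the values given here, no measured step involves this swap; the only measured step, chloro for trifluoromethyl, cannot be sized. Nothing in the data therefore points to a change beyond the scatter, and compound 4 is expected to sit close to compound 3, with an estimated step of a 1.0-fold lower number from compound 3 to compound 4 (0.00 log units; within the scatter). The estimate for compound 4 in this assay is 7500 nM, within 2500 nM to 25000 nM.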

Compound 4, half-maximal inhibitory concentration: 5850 nM
Beside the measured number, compound 4's estimate is 1.3-fold (0.11 log units) above it; measured number inside the range.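

In this assay, chloro in place of methoxy on the aromatic carbon para to a large group gives a 1.3-fold lower number from compound 3 to compound 4 (0.11 log units; within the scatter), so the two groups are not told apart at this place. For the compounds shown here, this is the first step that can be read; the one earlier step, between compound 1 and compound 2, cannot be read. Nothing shown gives a cause for this result.

From the compounds shown here alone, whether an amine or a carboxylic acid at this place would move the value beyond the scatter remains open. So does whether the swap of methoxy for chloro would read the same at another place on this ring.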